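Compound 4: methyl for fluoro at the trifluoromethyl

A few compounds are considered here, and "the series" means these few. Any claim that something is new, unique, unknown or untested is made for them only; others in the source may bear on it.

Compound 1 `CNc1cc(Oc2ccc(NC(=O)Nc3cccc(C(F)(F)F)c3)cc2)ncn1` gives 40 nM in an assay on isolated protein for inhibition of serine/threonine-protein kinase TNNI3K (Homo sapiens) (a higher number here means a weaker inhibitor, a lower number a stronger inhibitor), the second highest of the three numbers to hand. Compound 3 `CC(=O)Nc1cc(Oc2ccc(NC(=O)Nc3cccc(C(F)(F)F)c3)cc2)ncn1` gives 20 nM, and the step of a 2.0-fold lower number from compound 1 to compound 3 (0.30 log units; within the scatter) stays within the scatter. Compound 2 `O=C(Nc1ccc(Oc2ccncn2)cc1)Nc1cccc(C(F)(F)F)c1` gives 160 nM; the step of a 4.0-fold higher number from compound 1 to compound 2 (0.60 log units; beyond the scatter) lies beyond the scatter, as does an 8.0-fold lower number from compound 2 to compound 3 (0.90 log units; beyond the scatter). Compound 4 `CNc1cc(Oc2ccc(NC(=O)Nc3cccc(C(C)(F)F)c3)cc2)ncn1` differs from compound 1 in one place: methyl in place of fluoro on a saturated chain carbon bound to an aromatic carbon and two fluorine atoms. Going by the values given here, all three measured steps concern the methylamino, acetamido or hydrogen on the aromatic carbon of the shared core; none alters the trifluoromethyl, so no measured step bears directly on this change. With that part of the molecule untested, the expectation for compound 4 is a step of a 1.5-fold higher number from compound 1 to compound 4 (0.18 log units; within the scatter), not clearly beyond the scatter. Compound 4 is therefore estimated at 60 nM, within 25 nM to 150 nM.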

Compound 4, half-maximal inhibitory concentration: 40 nM
Compound 4: middle estimate off by 1.5-fold (0.18 log units), on the high side, and the stated range covers the measured number.
By their numbers in this assay, from the lowest: compounds 3, 1 and 4 (each within the scatter of the next); then compound 2.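

Trifluoromethyl to 1,1-difluoroethyl is the first change shown at this place, and in this assay it gives no change at the digits printed from compound 1 to compound 4 (within the scatter) with the rest of the molecule held constant. Methyl can therefore stand in place of one fluoro on this carbon without a step that can be told from the scatter. No measurement on hand bears on why this is so.
Still open, as far as these compounds go, is whether this carbon keeps the same reading with no fluorine on it, as in an ethyl or tert-butyl group, or when replaced by a nitrile. Also open, from the compounds shown here alone, is whether 1,1-difluoroethyl reads the same with acetamido in place of methylamino.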